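Adding a nitro group to compound 3

The compounds below may be only part of what the source reports. "The series", "measured", "known", "first", "only" and "open" are said of these compounds alone.

compound 1 `CC(=O)/C(C)=C/c1ccc([N+](=O)[O-])cc1`: 266000 nM
compound 2 `C/C(=C\c1ccccc1)C(=O)/C=C/c1ccc([N+](=O)[O-])cc1`: 43300 nM
compound 3 `C/C(=C\c1ccccc1)C(=O)/C=C/c1ccc(N(C)C)cc1`: 53000 nM

These values come from an ADME assay on LLC-MK2 cells (Macaca mulatta) for cytotoxicity, read by MTT assay, with a stated time of 48 h; a higher number here means that more compound is tolerated, a lower number that less compound is tolerated. Among the three compounds, compound 3, at 53000 nM, lies clearly below compound 1, at 266000 nM. Compound 3 cannot be told apart from compound 2, whose value is 43300 nM.

The next compound is compound 4 `C/C(=C\c1ccc([N+](=O)[O-])cc1)C(=O)/C=C/c1ccc(N(C)C)cc1`. It is compound 3 with nitro in place of hydrogen on an aromatic carbon, para to a large group: nitro in place of hydrogen on an aromatic carbon.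

Within the data shown here, only one measured step bears on this change: a 1.2-fold higher number from compound 2 to compound 3 (0.09 log units; within the scatter). That step puts dimethylamino in place of nitro, so it shows a nitro group being exchanged, though at a different place from the new one in compound 4. It stays within the scatter, and it is small evidence for a single change. Compound 1 also carries a nitro group, but it is a much smaller molecule and offers no matched comparison. Among the measured compounds shown here, no measured pair shows nitro replacing hydrogen, so the expectation remains uncertain.

The expected step, a 1.2-fold lower number from compound 3 to compound 4 (0.07 log units; within the scatter), is therefore none beyond the scatter. For compound 4 the estimated value is 45000 nM, within an expected range from 20000 nM to 100000 nM.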

Compound 4, half-maximal cytotoxic concentration: 25900 nM
The estimate for compound 4 lay 1.7-fold (0.24 log units) above the measured number, within the range that was stated.
By their numbers in this assay, from the lowest: compounds 4, 2 and 3 (each within the scatter of the next, the first and the last beyond it); then compound 1.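

Placing a nitro group on this aromatic carbon, para to a large group, gives the first direct view of nitro replacing hydrogen in this series: in this assay, the change produces a 2.0-fold lower number from compound 3 to compound 4 (0.31 log units; beyond the scatter). The step is modest, but it means that less compound is tolerated, whereas the earlier exchange of nitro for dimethylamino at a different place, a 1.2-fold higher number from compound 2 to compound 3 (0.09 log units; within the scatter), could not be told from repeat-to-repeat variation. Nothing measured here explains the step from hydrogen to nitro at this position.

The compounds shown leave open whether this position responds specifically to nitro or whether another group in the same place, such as an amine, a carboxylic acid or a fluorine atom, would shift the tolerated concentration to a similar extent. They also leave open whether the same step would appear if the dimethylamino group on the other side of the molecule were replaced by hydrogen or a methoxy group, since this single pair tests the change against only one partner.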